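Swapping a methylphenyl arm for naphthyl on a triazole linker

This account rests on a few compounds, and the source may have more. Where it says the series, first, only, none or still open, it means among the compounds named here.

Measured so far in a functional assay on ECa-109 cells for antiproliferative activity against ECa-109 cell line (Homo sapiens), read by MTT assay, with a stated time of 48 h; a lower number here means a stronger inhibitor, a higher number a weaker inhibitor:
Compound 1, `Cc1ccc(Cn2cc(CSc3nnc(-c4ccccc4)c(-c4ccccc4)n3)nn2)cc1`, gives 12400 nM.
Compound 2, `c1ccc(Cn2cc(Cc3nnc(-c4ccccc4)c(-c4ccccc4)n3)nn2)cc1`, gives 11100 nM.
Compound 3, `NS(=O)(=O)c1ccc(-n2cc(CSc3nnc(-c4ccccc4)c(-c4ccccc4)n3)nn2)cc1`, is reported only as a limit of the assay, > 100000 nM.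

Compound 1 stands at the higher of the two numbers actually measured, though its gap to compound 2 lies within the usual scatter, so the two cannot be ordered. Within the data shown here, compound 3 sits at the limit of > 100000 nM in this assay, at which 1 of the 3 values shown sits, which tells only that its number lies beyond what the assay could resolve.

Compound 4, `c1ccc(-c2nnc(SCc3cn(Cc4ccc5ccccc5c4)nn3)nc2-c2ccccc2)cc1`, differs from compound 1 by naphthalen-2-yl in place of 4-methylphenyl on a saturated chain carbon bound to an aromatic nitrogen. Among the measured compounds shown here, the only measured step that touches this arm is an at least 8.0-fold higher number from compound 1 to compound 3 (0.90 log units; beyond the scatter), which replaced the whole arm with a different group directly on the aromatic nitrogen, so it does not read across cleanly. Nothing measured isolates a change from methylphenyl to naphthyl on the chain carbon, and the step is therefore expected to stay within the scatter, a 1.2-fold lower number from compound 1 to compound 4 (0.09 log units; within the scatter). Compound 4 is estimated at 10000 nM, between 4000 nM and 30000 nM.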

Compound 4, half-maximal inhibitory concentration: > 100000 nM
Compound 4: no number, only a limit (the forecaster's own chance of this, stated with the estimate: 10%); middle value at least 10-fold (1.00 log units) away from the limit.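

Naphthalen-2-yl in place of 4-methylphenyl on a saturated chain carbon bound to an aromatic nitrogen gives, in this assay, an at least 8.0-fold higher number from compound 1 to compound 4 (0.90 log units; beyond the scatter). Before this, only compound 3, with a different group set directly on the aromatic nitrogen, had reached the top of the range, whereas compound 4 shows that exchanging one carbon-only aromatic group for another on the chain carbon is enough to do so. Compound 4 is reported only as a limit, so the true size of the step is unknown, and the step between compound 3 and compound 4 cannot be read, since both sit at the same limit: the limit of > 100000 nM in this assay, at which 2 of the 4 values shown sit.

The compounds shown leave open whether the second aromatic ring of the naphthyl group is what matters. A naphthalen-1-yl, 4-chlorophenyl or cyclohexyl group on the same chain carbon would help to separate these possibilities.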